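Swapping the Aryl Group on a Sulfonamide Chain

The compounds below may be only part of what the source reports. "The series", "measured", "known", "first", "only" and "open" are said of these compounds alone.

Compound 2 `COc1cccc(CNCCCNS(=O)(=O)c2cc(C(F)(F)F)cc(C(F)(F)F)c2)c1` is a sulfonamide whose chain ends in an amine nitrogen bearing a 3-methoxybenzyl group. Within the data shown here, in a functional assay on MIA PaCa-2 cells (Homo sapiens) for inhibition, read by MTT assay, with a stated time of 72 h (a lower number here means a stronger inhibitor of growth, a higher number a weaker inhibitor of growth), compound 2 gives 3400 nM, the highest of the two numbers measured so far. Among the measured compounds shown here, its nearest neighbour is compound 1 `O=S(=O)(NCCCNCc1cccc2ccccc12)c1cc(C(F)(F)F)cc(C(F)(F)F)c1`, which in this assay gives 2800 nM; the single change between them, naphthalen-1-yl against 3-methoxyphenyl on a saturated chain carbon bound to an amine nitrogen, gave a 1.2-fold higher number from compound 1 to compound 2 (0.08 log units; within the scatter).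

Compound 3 `O=S(=O)(NCCCNCc1ccc(C(F)(F)F)cc1)c1cc(C(F)(F)F)cc(C(F)(F)F)c1` has not yet been measured. It differs from compound 2 in one place: 4-(trifluoromethyl)phenyl in place of 3-methoxyphenyl on a saturated chain carbon bound to an amine nitrogen. For the measured compounds named here, the only step that bears on this is the one from compound 1 to compound 2, which changed the aryl group at the same place and stayed within the scatter. On that basis the step from compound 2 to compound 3 is expected to be small, a 1.1-fold lower number from compound 2 to compound 3 (0.05 log units; within the scatter), in no particular direction. Compound 3 is therefore estimated to give 3000 nM in this assay, with a likely range from 1200 nM to 7500 nM.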

Compound 3, concentration for 50% growth inhibition: 2500 nM
The estimate for compound 3 lay 1.2-fold (0.08 log units) above the measured number; low and high end bracket the measured number.
By their numbers in this assay, from the lowest: compounds 3, 1 and 2 (each within the scatter of the next).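

In this assay, the new compound adds two steps, a 1.4-fold lower number from compound 2 to compound 3 (0.13 log units; within the scatter) and a 1.1-fold lower number from compound 1 to compound 3 (0.05 log units; within the scatter), so three different aryl groups on a saturated chain carbon bound to an amine nitrogen now give numbers that cannot be told apart. Among these compounds, the earlier pair showed only a single swap, whereas this one also exchanges a group with an oxygen atom and 1 hydrogen-bond acceptor for one with 3 fluorine atoms and 0 hydrogen-bond acceptors, and even this change stays within the scatter. Nothing available explains why these exchanges leave the growth-inhibition number so little moved.

The compounds shown cover only aryl groups built from carbon rings, so they leave open whether a ring containing nitrogen, such as pyridinyl, a saturated ring such as cyclohexyl, or a carboxylic acid on the phenyl ring would produce a step beyond the scatter. They also leave open whether an amine on that ring, or a longer chain between the two nitrogen atoms, would matter more than the aryl swaps have so far.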